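The compounds below may be only part of what the source reports. "The series", "measured", "known", "first", "only" and "open" are said of these compounds alone.

Measured so far:
- compound 1, `CCN(Cc1ccc(Br)cc1)c1cccc(C(=O)N2CCc3ccc(OS(N)(=O)=O)cc3C2)c1`: 24.2%
- compound 2, `NS(=O)(=O)Oc1ccc2c(c1)CN(C(=O)c1ccc(N3CCC(Cc4ccccc4)CC3)cc1)CC2`: 41.4%

Both numbers come from an assay on HEK293 cells for inhibition of Steryl-sulfatase (Homo sapiens), tested at 0.1 uM; on this read-out higher numbers stand for a stronger effect at the one concentration tested and lower numbers for a weaker effect. Of the two, compound 1 gives the lower number; compound 2 gives a number above it, and that gap lies beyond the scatter. Going by the values given here, the two compounds differ in more than one place, so no single step between them can be read off.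

Compound 3, `CN(CCN1CCCCC1)c1cccc(C(=O)N2CCc3ccc(OS(N)(=O)=O)cc3C2)c1`, has not yet been measured. It differs from compound 1 in one place: methyl(2-(piperidin-1-yl)ethyl)amino in place of (4-bromobenzyl)(ethyl)amino on an aromatic carbon.

Among the compounds with values here, no step of this kind has been measured, so the expected size rests only on the value of compound 1. Within the data shown here, with no comparable step to lean on, the change from compound 1 to compound 3 is expected to be small, within the usual scatter, in either direction: a number 0.8 percentage points higher from compound 1 to compound 3 (within the scatter). For compound 3 in this assay the estimate is 25%, with a range from 8% to 45%.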

Compound 3, a percentage reported as inhibition, at one concentration (the size of the read-out at that concentration, not a potency): 24.5%
Compound 3: middle estimate off by 0.5 percentage points, on the high side; measured number inside the range.
By their numbers in this assay, from the lowest: compounds 1 and 3 (each within the scatter of the next); then compound 2.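

In this assay, going by these compounds alone, methyl(2-(piperidin-1-yl)ethyl)amino in place of (4-bromobenzyl)(ethyl)amino on the aromatic carbon gives a number 0.3 percentage points higher from compound 1 to compound 3 (within the scatter), the first single-place comparison. At this place, meta to a large group, the read-out does not separate a group with a six-membered aromatic ring of carbon only and a bromine from one with a six-membered non-aromatic ring and a second nitrogen. No measurement at hand accounts for the two groups reading alike.

Open, going by these compounds, is whether a primary amine or a carboxylic acid at this place would also leave the number within the scatter of compound 1. Also open, on these data alone, is whether a longer chain between the two nitrogens of the compound 3 substituent would move it.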